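Methylating a Phenol on Two Cores of Cytotoxic Dienones

This account rests on a few compounds, and the source may have more. Where it says the series, first, only, none or still open, it means among the compounds named here.

In a functional assay on HSC-2 cells (Homo sapiens) for cytotoxicity (a lower number here means that less compound is tolerated, a higher number that more compound is tolerated), three compounds have been measured. Compound 1 `COc1cc(/C=C2\Cc3ccccc3/C(=C\c3ccc([N+](=O)[O-])cc3)C2=O)ccc1O` gives 1450 nM. Compound 2 `COc1ccc(/C=C2\Cc3ccccc3/C(=C\c3ccc([N+](=O)[O-])cc3)C2=O)cc1OC` differs from compound 1 by methyl in place of hydrogen on an oxygen on an aromatic ring, and in this assay compound 2 gives 920 nM; the step is a 1.6-fold lower number from compound 1 to compound 2 (0.20 log units; within the scatter). Compound 3 `O=C1/C(=C/c2ccc(O)cc2)CCC/C1=C\c1ccc([N+](=O)[O-])cc1` carries a different core; how the cores of compound 3 and compound 1 differ is not broken down here. In this assay compound 3 gives 8100 nM, the highest of the three numbers, beyond the scatter from the other two.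

Compound 4 `COc1ccc(/C=C2\CCC/C(=C\c3ccc([N+](=O)[O-])cc3)C2=O)cc1` is not yet measured. It differs from compound 3 by methyl in place of hydrogen on an oxygen on an aromatic ring, the same change that led from compound 1 to compound 2, made at the same kind of place. Since that earlier step, a 1.6-fold lower number from compound 1 to compound 2 (0.20 log units; within the scatter), stayed within the scatter, a step of similar size is expected from compound 3 to compound 4, namely a 1.4-fold lower number from compound 3 to compound 4 (0.13 log units; within the scatter). Compound 4 is therefore estimated to give about 6000 nM in this assay, with a likely range from 2500 nM to 14000 nM.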

Compound 4, half-maximal cytotoxic concentration: > 400000 nM
Compound 4 ended at the assay's limit; the forecaster's own chance of this, stated with the estimate: 5%; middle value at least 66-fold (1.82 log units) away from the limit.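

In this assay, compound 4 gives > 400000 nM, which is a limit of the assay and not a number. Even read as a limit, hydroxy to methoxy on the core of compound 3 gives an at least 49-fold higher number from compound 3 to compound 4 (1.69 log units; beyond the scatter), so the small step seen on the core of compound 1 did not carry over, and the same change behaved very differently on the two cores: the same change on two cores in this assay, a 1.6-fold lower number (0.20 log units; within the scatter) from compound 1 to compound 2 and an at least 49-fold higher number (1.69 log units; beyond the scatter) from compound 3 to compound 4, at least 77-fold (1.89 log units) apart, beyond the scatter of two such steps This shows that a step measured on one core could not be used to predict the same step on the other here, but it does not show why the two differ, and the full size of the new step remains unknown, given the limit: the limit of > 400000 nM in this assay, at which 1 of the 4 values shown sits.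

The compounds shown leave open how a longer chain on that oxygen, such as ethyl, or an amine in place of the hydroxy would behave on the core of compound 3. They also leave open whether this methyl change on further cores would resemble the small step or the large one.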